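Swapping a thiazole for a thiophene on a nucleoside core

A few compounds are considered here, and "the series" means these few. Any claim that something is new, unique, unknown or untested is made for them only; others in the source may bear on it.

Measured in a functional assay on CCRF-CEM cells (Homo sapiens) for inhibition; a higher number here means a weaker inhibitor, a lower number a stronger inhibitor:
Compound 1 `OC[C@H]1OC(n2cnc3c(-c4cc[nH]c4)ncnc32)[C@H](O)[C@@H]1O`: 1030 nM
Compound 2 `OC[C@H]1OC(n2cnc3c(-c4nccs4)ncnc32)[C@H](O)[C@@H]1O`: 2730 nM

In this assay compound 2 gives the highest of the two numbers; its nearest neighbour is compound 1, reached by the step of a 2.7-fold higher number from compound 1 to compound 2 (0.42 log units; beyond the scatter), a modest step yet beyond the scatter. Compound 3 `OC[C@H]1OC(n2cnc3c(-c4ccsc4)ncnc32)[C@H](O)[C@@H]1O` differs from compound 2 by thiophen-3-yl in place of 1,3-thiazol-2-yl on an aromatic carbon. Only that one step is known, and it concerns a different pair of rings, so it bears loosely on this change; nothing shown points firmly in either direction. Compound 3 is therefore expected at an estimated 1600 nM, between 500 nM and 5000 nM. That estimate means an expected step of a 1.7-fold lower number from compound 2 to compound 3 (0.23 log units; within the scatter).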

Compound 3, half-maximal inhibitory concentration: 1640 nM
Beside the measured number, compound 3's estimate is 1.0-fold (0.01 log units) below it, within the range that was stated.
By their numbers in this assay, from the lowest: compounds 1, 3 and 2 (each within the scatter of the next, the first and the last beyond it).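

In this assay, thiophen-3-yl in place of 1,3-thiazol-2-yl gives a 1.7-fold lower number from compound 2 to compound 3 (0.22 log units; within the scatter) and thiophen-3-yl in place of 1H-pyrrol-3-yl gives a 1.6-fold higher number from compound 1 to compound 3 (0.20 log units; within the scatter) at this position. Compound 3 therefore cannot be told apart from either neighbour, even though those two neighbours differ from each other beyond the scatter, so all three five-membered aromatic rings fall within a narrow range here. Nothing measured explains these small differences. Still open, going by these compounds, is how this position responds to something other than a five-membered aromatic ring, such as an amine or a longer carbon chain.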